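Trithiocarbonate ketone amides: benzyl versus phenyl on nitrogen

This account rests on a few compounds, and the source may have more. Where it says the series, first, only, none or still open, it means among the compounds named here.

Measured so far:
compound 1 `CCSC(=S)SCC(=O)c1ccc(C(=O)N[C@@H](C)c2ccccc2)s1` — 135 nM
compound 2 `CCSC(=S)SCC(=O)c1cccc(C(=O)NCc2ccccc2)c1` — 195 nM
compound 3 `CCSC(=S)SCC(=O)c1cccc(NS(=O)(=O)c2ccc(Cl)cc2)c1` — 1250 nM

The three compounds share a trithiocarbonate ketone attached to an aromatic core and differ in the group carried on that core. In an assay on HEK293 cells for inhibition of protein deacetylase HDAC6 (Homo sapiens) (on this read-out lower numbers stand for stronger inhibition and higher numbers for weaker inhibition), compound 1 gives 135 nM and compound 2 gives 195 nM; these two lie within the scatter of each other, so no order can be read between them. Compound 3 gives 1250 nM, well beyond the scatter above both of the amides. Compound 2 thus stands second highest of the three numbers, close to compound 1 and far from compound 3.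

The next compound, compound 4 `CCSC(=S)SCC(=O)c1cccc(C(=O)Nc2ccccc2)c1`, keeps the core of compound 2 and changes only the substituent on the amide-type nitrogen: phenyl in place of benzyl on an amide-type nitrogen.

For the measured compounds named here, no measured pair shows this change, so its effect is open. The two amides sit together and the only non-amide, compound 3, sits far above them; the step from compound 2 to compound 4 is expected to be a modest weakening, a 1.8-fold higher number from compound 2 to compound 4 (0.25 log units; within the scatter), about at the edge of the scatter. Compound 4 is accordingly estimated at 350 nM, with a range from 120 nM to 1000 nM.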

Compound 4, half-maximal inhibitory concentration: 517 nM
Beside the measured number, compound 4's estimate is 1.5-fold (0.17 log units) below it; the range from low to high includes it.
By their numbers in this assay, from the lowest: compounds 1 and 2 (each within the scatter of the next); then compound 4; then compound 3.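

For the compounds shown here, on the amide-type nitrogen, phenyl in place of benzyl gives (a 2.7-fold higher number from compound 2 to compound 4 (0.42 log units; beyond the scatter)), the first step read at a single place, so the number responds to the group on this nitrogen. Benzyl and phenyl each carry one six-membered aromatic ring of carbon only, with no hydrogen-bond donors or acceptors, and differ only by 7 against 6 heavy atoms, so the ring alone does not set the number here. No available data account for this step.

As far as these compounds go, whether a longer chain on this nitrogen, such as phenethyl, would continue in the same direction remains open. Also open, from the compounds shown here alone, are the effects of a pyridyl ring in place of the phenyl and of a methyl group on the amide nitrogen itself.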